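The source may hold more compounds than are shown below. What is called first, only, known or untested is meant among the compounds shown, and "the series" means these compounds.

Compound 1 `CN(Cc1cccc(F)c1)C(=O)CCCNC(=O)c1ccc(S(C)(=O)=O)c([N+](=O)[O-])c1` belongs to a small set built on a shared core joined through an amide to a saturated chain that ends in a carbonyl carbon. In an assay on isolated protein for inhibition of thyroid hormone receptor alpha (Homo sapiens), read by fluorescence polarization (a lower number here means a stronger inhibitor, a higher number a weaker inhibitor), compound 1 gives > 60000 nM, which is a limit of the assay and not a number. Compound 2 `CN(CC(=O)N1CCN(c2ccc(F)cc2)CC1)C(=O)c1ccc(S(C)(=O)=O)c([N+](=O)[O-])c1` likewise stops at a limit, giving > 60000 nM in this assay. Among the compounds with values here, compound 3 `CS(=O)(=O)c1ccc(C(=O)NCC(=O)N2CCCCC2)cc1[N+](=O)[O-]` is the only member with a numerical reading, coming in at 44000 nM in this assay. Compound 1 thus stands at the limit of > 60000 nM in this assay, at which 2 of the 3 values shown sit, with nothing below the boundary to separate it from compound 2.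

The step to compound 4 `CC1CCN(C(=O)CCCNC(=O)c2ccc(S(C)(=O)=O)c([N+](=O)[O-])c2)CC1`, not yet measured in this assay, changes one group: 4-methylpiperidin-1-yl in place of (3-fluorobenzyl)(methyl)amino on a carbonyl carbon. Within the data shown here, no pair of measured compounds differs in only one place, so no measured step exists that could guide this change. The step from compound 1 to compound 4 is estimated at a step that the limit leaves unreadable from compound 1 to compound 4, and it is not expected to lie beyond the scatter in either direction. Compound 4 is therefore expected to come in around 70000 nM, with a range from 30000 nM to 200000 nM, and a strong chance that this assay again reports only a limit.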

Compound 4, half-maximal inhibitory concentration: > 60000 nM
Compound 4 gave a limit, no number; the forecaster's own chance of this, stated with the estimate: 70%; the middle value lies beyond the limit too.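

Within the data shown here, compound 4 stops at a limit in this assay, just as compound 1 does, so no step from compound 1 to compound 4 can be read: the limit of > 60000 nM in this assay, at which 3 of the 4 values shown sit. The compounds shown leave open whether 4-methylpiperidin-1-yl in place of (3-fluorobenzyl)(methyl)amino on a carbonyl carbon changes the inhibition at all.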